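Aryl exchange on the aromatic-ring nitrogen, compound 2 to 3

A few compounds are considered here, and "the series" means these few. Any claim that something is new, unique, unknown or untested is made for them only; others in the source may bear on it.

Among the compounds with values here, compound 2 `C=CC(=O)Nc1cccc(NC(=O)CSc2nc(Nc3ccc(CC)cc3)c3ccccc3n2)c1` gives 8010 nM in a functional assay on MGC-803 cells (Homo sapiens) for inhibition, read by MTT assay, with a stated time of 72 h (on this read-out lower numbers stand for stronger inhibition and higher numbers for weaker inhibition), the upper of the two numbers so far, with compound 1 `C=CC(=O)Nc1cccc(NC(=O)CSc2nc(Nc3cccc(F)c3)c3ccccc3n2)c1` at 6250 nM lying within the scatter of it. Within the data shown here, the one measured step, a 1.3-fold higher number from compound 1 to compound 2 (0.11 log units; within the scatter), is itself an exchange of the aryl group on this nitrogen. Compound 3 `C=CC(=O)Nc1cccc(NC(=O)CSc2nc(Nc3cc(OC)c(OC)c(OC)c3)c3ccccc3n2)c1` carries 3,4,5-trimethoxyphenyl in place of 4-ethylphenyl on a nitrogen on an aromatic ring. Among the measured compounds shown here, since the single comparable exchange stayed within the scatter, no step beyond the scatter is expected, and the expected change is a 1.1-fold lower number from compound 2 to compound 3 (0.06 log units; within the scatter). For compound 3 the estimate in this assay is 7000 nM, ranging from 2500 nM to 20000 nM.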

Compound 3, half-maximal inhibitory concentration: > 50000 nM
Compound 3: only a limit was reported; the forecaster's own chance of this, stated with the estimate: 5%; at least 7.1-fold (0.85 log units) between middle value and limit.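

In this assay compound 3 gives > 50000 nM, which is a limit of the assay and not a number. The aryl group on this nitrogen can therefore matter: the new exchange reads as an at least 6.2-fold higher number from compound 2 to compound 3 (0.79 log units; beyond the scatter) and as an at least 8.0-fold higher number from compound 1 to compound 3 (0.90 log units; beyond the scatter), while the earlier exchange, a 1.3-fold higher number from compound 1 to compound 2 (0.11 log units; within the scatter), stayed within the scatter. Of the three aryl groups shown, only 3,4,5-trimethoxyphenyl gives steps beyond the scatter.

On these data alone, whether a single methoxy group on the phenyl ring would give such a step remains open. As far as these compounds go, the effect of an amine on that ring is equally open.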